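Two measured, one pending: side-chain changes in the series

The source may report more compounds than this note shows. Statements on the series, on what has been measured and on what is new or still open speak of the compounds shown alone.

Compound 1 `CCC[C@@H](NC(=O)c1cnccn1)C(=O)N[C@@H](CC(C)C)B(O)O` gives 187 nM in an assay on isolated protein for inhibition of Lon protease homolog, mitochondrial (Homo sapiens), read by HTRF, with a stated time of 50 min, in the presence of a further agent that is not named here; on this read-out higher numbers stand for weaker inhibition and lower numbers for stronger inhibition.
Compound 2 `CCCC[C@@H](NC(=O)c1cnccn1)C(=O)N[C@@H](CC(C)C)B(O)O` gives 93 nM in this assay.

Going by the values given here, compound 1 stands with the highest of the two numbers so far; its nearest neighbour is compound 2, and the only measured step is a 2.0-fold lower number from compound 1 to compound 2 (0.30 log units; within the scatter), a change that sits four bonds along the chain from an amide-type nitrogen and a carbonyl carbon and does not reach beyond the scatter.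

Compound 3 `CCCC[C@H](NC(=O)[C@@H](CCC)NC(=O)c1cnccn1)B(O)O` is not yet measured in this assay. Relative to compound 1 the change is propyl in place of isopropyl on a saturated chain carbon, two bonds along the chain from an amide-type nitrogen and a boron atom. Among the compounds with values here, no measured step touches the saturated chain carbon two bonds from the amide-type nitrogen and the boron atom; the step from compound 1 to compound 2 concerns the other chain and is itself within the scatter, so it offers no direction for this position. The expectation is therefore a step no larger than the scatter, with wide uncertainty. For compound 3 the estimate is 250 nM, spanning 90 nM to 700 nM, which as a step is expected to read a 1.3-fold higher number from compound 1 to compound 3 (0.13 log units; within the scatter).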

Compound 3, half-maximal inhibitory concentration: 38 nM
For compound 3 the middle estimate is 6.6-fold (0.82 log units) above the measured one, and the stated range ends above it.
By their numbers in this assay, from the lowest: compound 3; then compounds 2 and 1 (each within the scatter of the next).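

Working notes on the series: at the saturated chain carbon two bonds along the chain from an amide-type nitrogen and a boron atom, replacing isopropyl with propyl gives a 4.9-fold lower number from compound 1 to compound 3 (0.69 log units; beyond the scatter) in this assay. Going by these compounds alone, this is the first step to lie beyond the scatter, and it comes from an exchange of a branched chain for an unbranched one with the heavy-atom count unchanged, whereas the only earlier step, on the other chain, reads a 2.0-fold lower number from compound 1 to compound 2 (0.30 log units; within the scatter) and so gave no direction for this position. Nothing available explains why this change moves the number.

Open, as far as these compounds go, is whether a longer chain such as pentyl at this position would extend the trend from isopropyl to propyl, or whether a ring-bearing group such as benzyl or cyclohexylmethyl would hold the lower number. Also open is whether the unbranched chain at this position and the longer chain on the other side would act independently, since the compounds shown give no single-place comparison that tests the two changes together.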